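Aryl-piperazine aminothiophenes: a chloro added to the fluorophenyl

This account rests on a few compounds, and the source may have more. Where it says the series, first, only, none or still open, it means among the compounds named here.

Measured compounds:
Compound 1: `CC(C)N1CCN(Cc2csc(N)c2C(=O)c2ccc(Cl)cc2)CC1` with -1% in a functional assay on CHO cells with adenosine receptor A1 (Homo sapiens) as the target, read by cAMP accumulation and immunoassay, with a stated time of 6 min, tested at 0.01 uM; a higher number here means a weaker effect of the compound at the concentration tested, a lower number a stronger effect
Compound 2: `Nc1scc(CN2CCN(c3cccc(F)c3)CC2)c1C(=O)c1ccc(Cl)cc1` with -18% in this assay

The two measured compounds share one core and differ only in the group on an amine nitrogen in a ring. Going from the isopropyl to the 3-fluorophenyl gave a number 17 percentage points lower from compound 1 to compound 2 (beyond the scatter), a step the data mark as beyond the scatter. Compound 2 therefore stands at the lowest of the two numbers, with compound 1 the nearest and higher.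

Compound 3, `Nc1scc(CN2CCN(c3ccc(F)c(Cl)c3)CC2)c1C(=O)c1ccc(Cl)cc1`, is not yet measured. It differs from compound 2 by 3-chloro-4-fluorophenyl in place of 3-fluorophenyl on an amine nitrogen in a ring. Among the compounds with values here, no measured step concerns an added chlorine on this aryl ring; the only step on record, from isopropyl to 3-fluorophenyl, changed the group far more than a single added atom does. Compound 3 is accordingly expected to remain near compound 2, with a number 2 percentage points lower from compound 2 to compound 3 (within the scatter) as the expected step, within the scatter. The estimate for compound 3 in this assay is -20%, with a range from -40% to 0%.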

Compound 3, a percentage reported as activity, at one concentration (the size of the read-out at that concentration, not a potency): 4.2%
The estimate for compound 3 lay 24.2 percentage points below the measured number, and the stated range ends below it.
By their numbers in this assay, from the lowest: compound 2; then compounds 1 and 3 (each within the scatter of the next).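

In this assay, the group on an amine nitrogen in a ring proved sensitive to a change confined to the substituents of one aromatic ring: 3-chloro-4-fluorophenyl in place of 3-fluorophenyl gave a number 22.2 percentage points higher from compound 2 to compound 3 (beyond the scatter). Having an aryl group at this position therefore does not by itself set the number, since 3-chloro-4-fluorophenyl in place of isopropyl gave only a number 5.2 percentage points higher from compound 1 to compound 3 (within the scatter), whereas the 3-fluorophenyl step from the same isopropyl compound was beyond the scatter. No available measurement gives a reason for this shift.

The compounds shown leave open whether the shift follows the chlorine or the different place of the fluorine, which the group names put at 3 in compound 2 and at 4 in compound 3; 3-chlorophenyl and 4-fluorophenyl on the same nitrogen would separate the two. Also open, as far as these compounds go, are where an unsubstituted phenyl or a methoxyphenyl would fall, and whether these differences at a single concentration would carry over to potency.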